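This account rests on a few compounds, and the source may have more. Where it says the series, first, only, none or still open, it means among the compounds named here.

Measured in a functional assay on SH-SY5Y cells (Homo sapiens) for cytotoxicity, read by MTT assay, with stated times of 24 h and 4 h; on this read-out higher numbers stand for an effect only at larger amounts of compound and lower numbers for an effect already at smaller amounts:
compound 1, `COc1cccc(/C=C/C(=O)NCc2ccc(OCc3nc(C)c(C)nc3C)c(OC)c2)c1`, gives 4320 nM;
compound 2, `COc1cc(CNC(=O)/C=C/c2cccc(OC)c2OC)ccc1O`, gives 5490 nM;
compound 3, `COc1ccc(/C=C/C(=O)NCc2ccc(OCc3nc(C)c(C)nc3C)c(OC)c2)cc1OC`, gives 4470 nM.

Compound 3 differs from compound 1 by methoxy in place of hydrogen on an aromatic carbon, and this change gave a 1.0-fold higher number from compound 1 to compound 3 (0.01 log units; within the scatter). Compound 2 and compound 1 have different cores, and the difference between the two cores is not broken down here; their values in this assay lie within the scatter of each other. Compound 4, `COc1cc(CNC(=O)/C=C/c2ccc(OC)c(OC)c2OC)ccc1O`, is not yet measured. It differs from compound 2 by methoxy in place of hydrogen on an aromatic carbon. The place is not the same word for word as in the change from compound 1 to compound 3: in compound 4 the entering methoxy is also meta to a methoxy group, so this is the same kind of change rather than the same one. Among the compounds with values here, the expected step from compound 2 to compound 4 in this assay is a 1.0-fold higher number from compound 2 to compound 4 (0.00 log units; within the scatter), resting on the unchanged number seen in a 1.0-fold higher number from compound 1 to compound 3 (0.01 log units; within the scatter), while the core of compound 2 carries no measured step of this kind. Compound 4 is therefore estimated at 5500 nM, with a range from 2800 nM to 11000 nM.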

Compound 4, half-maximal effective concentration: 7450 nM
Estimate against measurement, compound 4: 1.4-fold (0.13 log units) below; the measured number falls inside the stated range.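

In this assay, methoxy in place of hydrogen on an aromatic carbon gives a 1.4-fold higher number from compound 2 to compound 4 (0.13 log units; within the scatter), and the core of compound 2 thus behaves as the core of compound 1 did under the same kind of change. Set side by side, the two steps do not differ: the same change on two cores in this assay, a 1.0-fold higher number (0.01 log units; within the scatter) from compound 1 to compound 3 and a 1.4-fold higher number (0.13 log units; within the scatter) from compound 2 to compound 4, 1.3-fold (0.12 log units) apart, within the scatter of two such steps. Within the data shown here, this shows that on these two cores the added methoxy left the read-out within the scatter, but it rests on only two pairs, in one cell assay, and in compound 4 the entering methoxy is also meta to a methoxy group, so it does not show that the change would carry to other cores or other places on the ring.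

The compounds shown leave open what an amine or a carboxylic acid would do in place of this methoxy. They also leave open whether a longer chain on that oxygen, such as ethoxy or propoxy, would stay within the scatter on either core.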